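The compounds below may be only part of what the source reports. "The series", "measured", "known", "first", "only" and "open" are said of these compounds alone.

Measured so far in a functional assay on HeLa cells for agonist activity at 5-hydroxytryptamine receptor 6 (Homo sapiens), read by cAMP accumulation and immunoassay; a higher number here means that more compound is needed for the effect, a lower number that less compound is needed:
compound 1 `CN1CCC(n2cc(S(=O)(=O)c3ccccc3)c3cccnc32)C1` gives 2040 nM
compound 2 `CN1CCC(n2cc(S(=O)(=O)c3cccc(F)c3)c3cccnc32)C1` gives 231 nM
compound 3 `O=S(=O)(c1ccccc1)c1cn(C2CCCNC2)c2ncccc12` gives 47 nM

Compound 3 holds the lowest number of the three; compound 2 comes nearest, compound 1 furthest, both beyond the scatter. Against compound 1 the step of a 43-fold lower number from compound 1 to compound 3 (1.64 log units; beyond the scatter) was large. The next compound, compound 4 `O=S(=O)(c1ccccc1Cl)c1cn(C2CCCNC2)c2ncccc12`, differs from compound 3 by chloro in place of hydrogen on an aromatic carbon (phenyl to 2-chlorophenyl). Within the data shown here, the only measured step of the same kind is a halogen on the same ring, an 8.8-fold lower number from compound 1 to compound 2 (0.95 log units; beyond the scatter), which was modest; no measured step places a halogen ortho to a large group. On that basis a modest lowering in this assay is expected for compound 4, a 1.9-fold lower number from compound 3 to compound 4 (0.27 log units; within the scatter), with the ring position left open. The estimated value for compound 4 is 25 nM, within 8 nM to 80 nM.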

Compound 4, half-maximal effective concentration: 50 nM
Compound 4: middle estimate off by 2.0-fold (0.30 log units), on the low side, and the stated range covers the measured number.
By their numbers in this assay, from the lowest: compounds 3 and 4 (each within the scatter of the next); then compound 2; then compound 1.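

In this assay, chloro in place of hydrogen ortho to a large group gives a 1.1-fold higher number from compound 3 to compound 4 (0.03 log units; within the scatter), so phenyl to 2-chlorophenyl leaves the number unchanged within the scatter. The earlier halogen step, an 8.8-fold lower number from compound 1 to compound 2 (0.95 log units; beyond the scatter), lies beyond the scatter, but it starts from a different compound and carries fluoro, so no general halogen trend follows. No supporting data account for this result.

Open, going by these compounds, is whether a methoxy group or an amine at this position would move the number beyond the scatter. Also open, on these data alone, is how chloro behaves elsewhere on the phenyl ring.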